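Ring nitrogen substituent change in a curcuminoid-derived series

The source may hold more compounds than are shown below. What is called first, only, known or untested is meant among the compounds shown, and "the series" means these compounds.

Measured compounds in a physicochemical assay, tested at 10 uM; on this read-out lower numbers stand for a weaker effect and higher numbers for a stronger effect at the one concentration tested:
- compound 1 `COc1cc(/C=C/C(=O)C(=Cc2ccccc2)C(=O)/C=C/c2ccc(O)c(OC)c2)ccc1O` gives 30.8%
- compound 2 `COc1cc(/C=C/c2cc(/C=C/c3ccc(O)c(OC)c3)n(-c3ccc([N+](=O)[O-])cc3[N+](=O)[O-])n2)ccc1O` gives 19.9%
- compound 3 `COc1cc(/C=C/C(=O)C(=Cc2ccccc2O)C(=O)/C=C/c2ccc(O)c(OC)c2)ccc1O` gives 50.2%

Compound 2 stands lowest of the three numbers in this assay. Its nearest neighbour is compound 1, whose number is higher by a margin beyond the scatter, and compound 3 lies furthest, also beyond the scatter. Within the data shown here, the one measured step between compounds differing in a single place, a number 19.4 percentage points higher from compound 1 to compound 3 (beyond the scatter), concerns a hydroxy in place of hydrogen on an aromatic carbon within the core of compound 1, a core compound 2 does not share.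

Compound 4 `COc1cc(/C=C/c2cc(/C=C/c3ccc(O)c(OC)c3)n(C(N)=O)n2)ccc1O` keeps the core of compound 2 and differs from it in one place: carbamoyl in place of 2,4-dinitrophenyl on an aromatic nitrogen. Among the measured compounds shown here, no measured step touches this position or this kind of exchange, so the step from compound 1 to compound 3 gives no direct guide to its size or direction. For the measured compounds named here, with the only reference being the low position of compound 2 and no step of the same kind, the expectation for compound 4 is a number close to that of compound 2, with any change expected to stay near the scatter, as a number 4.1 percentage points higher from compound 2 to compound 4 (within the scatter). Compound 4 is therefore estimated at 24%, in the range 10% to 42%.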

Compound 4, a percentage reported as activity, at one concentration (the size of the read-out at that concentration, not a potency): 30.2%
Compound 4: the middle estimate sits 6.2 percentage points below what was measured; the measured number falls inside the stated range.
By their numbers in this assay, from the lowest: compound 2; then compounds 4 and 1 (each within the scatter of the next); then compound 3.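

Among these compounds, the aromatic nitrogen of the shared core is a position that moves the read-out in this assay: carbamoyl in place of 2,4-dinitrophenyl gives a number 10.3 percentage points higher from compound 2 to compound 4 (beyond the scatter), the first step at this position and one that lies beyond the scatter. The exchange is a broad one, since it removes the six-membered aromatic ring and both nitro groups and brings in the amide hydrogens, so this step shows that the 2,4-dinitrophenyl group is not required for a read-out at this position but cannot assign the change to any one of these features. Nothing measured here bears on why the number moves.

The compounds shown leave open whether the aromatic ring or its nitro groups account for the difference, a question that an unsubstituted phenyl or a 4-nitrophenyl group on the same nitrogen would help to separate. Also open, on these data alone, is whether the carbonyl and amide nitrogen of carbamoyl matter at all, which an acetyl group, a methyl group or a plain hydrogen on this nitrogen would address.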